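Chloro to bromo on the 4-chlorophenyl group

The compounds below may be only part of what the source reports. "The series", "measured", "known", "first", "only" and "open" are said of these compounds alone.

Among the compounds with values here, in a functional assay on HeLa cells (Homo sapiens) for cytotoxicity, read by MTT assay, with a stated time of 24 h (on this read-out lower numbers stand for stronger inhibition and higher numbers for weaker inhibition), compound 1 `COc1cc(/C=C2\CN(C)C/C(=C\c3ccccc3F)C2=O)cc(OC)c1` gives 5450 nM and compound 2 `COc1cc(/C=C2\CN(C)C/C(=C\c3ccc(Cl)cc3)C2=O)cc(OC)c1` gives 11200 nM, the higher of the two numbers so far. Compound 3 `COc1cc(/C=C2\CN(C)C/C(=C\c3ccc(Br)cc3)C2=O)cc(OC)c1` has bromo in place of chloro on an aromatic carbon. Within the data shown here, the only measured step, a 2.1-fold higher number from compound 1 to compound 2 (0.31 log units; beyond the scatter), is modest and exchanges 2-fluorophenyl for 4-chlorophenyl, so it bears only loosely on this change. The expected step in this assay is a 1.1-fold lower number from compound 2 to compound 3 (0.03 log units; within the scatter), with none expected beyond the scatter. For compound 3 the estimated value is 10500 nM, with an expected range of 5500 nM to 20000 nM.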

Compound 3, half-maximal inhibitory concentration: 5900 nM
Compound 3: the middle estimate sits 1.8-fold (0.25 log units) above what was measured, within the range that was stated.
By their numbers in this assay, from the lowest: compounds 1, 3 and 2 (each within the scatter of the next, the first and the last beyond it).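

In this assay, bromo in place of chloro on this aromatic carbon gives a 1.9-fold lower number from compound 2 to compound 3 (0.28 log units; within the scatter), so this exchange does not separate the two halogens here. The change from 2-fluorophenyl to 4-bromophenyl gives a 1.1-fold higher number from compound 1 to compound 3 (0.03 log units; within the scatter), so the step beyond the scatter seen with 4-chlorophenyl does not recur with 4-bromophenyl. No measurement offered here explains these results. Still open, from the compounds shown here alone, is how an amine or a carboxylic acid in place of the halogen at this position would read in this assay.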